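Swapping the Amine End of a Biguanide Pair

A few compounds are considered here, and "the series" means these few. Any claim that something is new, unique, unknown or untested is made for them only; others in the source may bear on it.

Compound 1, `N=C(NC(=N)NC1CCCC1)Nc1ccc(C(F)(F)F)cc1`: 3700 nM
Compound 2, `CCN(CC)C(=N)NC(=N)Nc1ccc(F)c(F)c1`: 44800 nM

Of the compounds shown here, two sharing the same core have been measured in a functional assay on T-24 cells (Homo sapiens) for antiproliferative activity, read by MTT assay, with a stated time of 72 h; on this read-out lower numbers stand for stronger inhibition and higher numbers for weaker inhibition. Compound 1 gives 3700 nM. Compound 2 gives 44800 nM, the higher of the two numbers and therefore the weaker inhibitor of the pair; its gap to compound 1 lies beyond the scatter. The two compounds differ in two places at once, so neither change can be credited on its own.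

Compound 3, `N=C(NC(=N)NC1CCCC1)Nc1ccc(F)c(F)c1`, has not yet been measured. Relative to compound 2 the change is cyclopentylamino in place of diethylamino on a carbon with a double bond to nitrogen. This brings the amine end of compound 3 into line with compound 1 while the aryl end stays as in compound 2. Because compound 1 gives 3700 nM with that same entering group, the number for compound 3 is expected to move downward in this assay, by a step beyond the scatter but not all the way to compound 1, since the second difference remains. The estimated value for compound 3 is 11000 nM, with a range from 3500 nM to 35000 nM, an expected step of a 4.1-fold lower number from compound 2 to compound 3 (0.61 log units; beyond the scatter).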

Compound 3, half-maximal inhibitory concentration: 24900 nM
For compound 3 the middle estimate is 2.3-fold (0.35 log units) below the measured one, within the range that was stated.
By their numbers in this assay, from the lowest: compound 1; then compounds 3 and 2 (each within the scatter of the next).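

In this assay, putting cyclopentylamino in place of diethylamino on a carbon with a double bond to nitrogen amounts to a 1.8-fold lower number from compound 2 to compound 3 (0.26 log units; within the scatter), so with the aryl end held fixed, this swap at the amine end cannot be told apart from the usual spread of repeated measurements. The entering group brings a five-membered ring of carbon only and a hydrogen-bond donor, neither of which diethylamino has, and even so the two compounds cannot be separated in this read-out. Nothing available here offers an explanation for this result.

From the compounds shown here alone, with cyclopentylamino on both, compound 1 gives 3700 nM and compound 3 gives 24900 nM, which leaves the aryl end, carrying trifluoromethyl in compound 1, as the one place where these two differ, and how much that place contributes remains open. Also open, going by these compounds, is whether a different amine end, such as dimethylamino or a longer chain like hexylamino, would give a step beyond the scatter at this position.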